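The source may report more compounds than this note shows. Statements on the series, on what has been measured and on what is new or still open speak of the compounds shown alone.

Measured so far:
compound 1 `NC(=O)c1cccc(-c2cnc(C(=O)CCCCCCc3ccccc3)o2)c1` — 2700 nM
compound 2 `Cc1ccnc(-c2cnc(C(=O)CCCCCCc3ccccc3)o2)c1` — 1 nM
compound 3 `COc1ncc(-c2cnc(C(=O)CCCCCCc3ccccc3)o2)c(OC)n1` — 9000 nM

Of the compounds shown here, three sharing one core have been measured in an assay (Rattus norvegicus) for inhibition of Fatty-acid amide hydrolase 1 (Homo sapiens); on this read-out higher numbers stand for weaker inhibition and lower numbers for stronger inhibition. Compound 1 `NC(=O)c1cccc(-c2cnc(C(=O)CCCCCCc3ccccc3)o2)c1` gives 2700 nM in this assay, the second highest of the three numbers. Its nearest neighbour is compound 3 `COc1ncc(-c2cnc(C(=O)CCCCCCc3ccccc3)o2)c(OC)n1`, which gives 9000 nM in this assay; the furthest is compound 2 `Cc1ccnc(-c2cnc(C(=O)CCCCCCc3ccccc3)o2)c1`, which gives 1 nM in this assay. For the measured compounds named here, the only step between compounds differing in one place is a 2700-fold lower number from compound 1 to compound 2 (3.43 log units; beyond the scatter).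

Compound 4 `O=C(CCCCCCc1ccccc1)c1ncc(-c2cc(=O)[nH]c(=O)[nH]2)o1` has not yet been measured in this assay. It differs from compound 1 as follows: a group of 8 heavy atoms (4 carbon, 2 nitrogen, 2 oxygen; one six-membered aromatic ring with 2 hetero atoms) in place of a group of 9 heavy atoms (7 carbon, 1 nitrogen, 1 oxygen; one six-membered aromatic ring of carbon only), on an aromatic carbon. Going by the values given here, the one measured step, a 2700-fold lower number from compound 1 to compound 2 (3.43 log units; beyond the scatter), shows that a change at this same position of the core can move the number enormously, yet it exchanges the 3-carbamoylphenyl for a different group than the one entering here, so it gives direction only loosely. Compound 3 carries a six-membered ring with two hetero atoms at this position and gives the highest number of the three, which points more toward a weaker rather than a stronger outcome for compound 4. On that basis compound 4 is expected to show a step of a 3.7-fold higher number from compound 1 to compound 4 (0.57 log units; beyond the scatter) in this assay, toward a higher number. The estimate for compound 4 in this assay is 10000 nM, expected to lie between 2000 nM and 50000 nM.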

Compound 4, half-maximal inhibitory concentration: 5 nM
Compound 4: the middle estimate sits 2000-fold (3.30 log units) above what was measured, outside the stated range (below it).
By their numbers in this assay, from the lowest: compound 2; then compound 4; then compound 1; then compound 3.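

The result shows that in this assay a low number at this position is not tied to the 4-methylpyridin-2-yl of compound 2: the entering group, with its six-membered aromatic ring with 2 hetero atoms, also gives a 540-fold lower number from compound 1 to compound 4 (2.73 log units; beyond the scatter) and so stays close to that pyridine, at a 5.0-fold higher number from compound 2 to compound 4 (0.70 log units; beyond the scatter), a modest step set against the large one that separates it from the 3-carbamoylphenyl. It also shows that a six-membered aromatic ring with 2 hetero atoms on this aromatic carbon does not by itself bring a high number, since compound 3 with such a ring gives 9000 nM while compound 4 gives 5 nM in the same assay. Nothing given here accounts for these differences.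

The compounds shown leave open which part of the entering group goes with the low number, and a version with a methyl on each ring nitrogen, or with a single ring carbonyl, would begin to separate those parts. They also leave open how a carboxylic acid or an amine would compare with these groups on the same aromatic carbon.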